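The source may hold more compounds than are shown below. What is called first, only, known or untested is meant among the compounds shown, and "the series" means these compounds.

Measured compounds in a functional assay on UACC-62 cells (Homo sapiens) for inhibition, read by sulforhodamine B assay, with a stated time of 48 h, tested at 10 uM; on this read-out higher numbers stand for more inhibition at the one concentration tested (going by the name of the read-out) and lower numbers for less inhibition:

compound 1 `Brc1cn2ccnc2c(-c2ccc3ncn(C4CCCCC4)c3c2)n1` — 19.8%
compound 2 `COc1ccc(-c2cn3ccnc3c(-c3ccc4ncn(C5CCCCC5)c4c3)n2)cc1` — 65.2%
compound 3 `Fc1ccc(-c2cn3ccnc3c(-c3ccc4ncn(C5CCCCC5)c4c3)n2)cc1` — 31%

Compound 3 sits second of the three numbers. Its nearest neighbour is compound 1, reached by a number 11.2 percentage points higher from compound 1 to compound 3 (beyond the scatter); its furthest is compound 2, separated by a number 34.2 percentage points lower from compound 2 to compound 3 (beyond the scatter). Within the set, replacing bromo on the shared core by an aryl group has moved the read-out upward in both cases, with the 4-methoxyphenyl step a number 45.4 percentage points higher from compound 1 to compound 2 (beyond the scatter) far larger than the 4-fluorophenyl step.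

Compound 4 `c1csc(-c2cn3ccnc3c(-c3ccc4ncn(C5CCCCC5)c4c3)n2)c1` is not yet measured. It differs from compound 3 as follows: thiophen-2-yl in place of 4-fluorophenyl on an aromatic carbon. Going by the values given here, no measured step exchanges one aryl group for a five-membered heteroaryl, so the relevant steps are only indirectly informative: the aryl-for-bromo steps from compound 1 show that an aromatic ring at this position raises the read-out, while the gap between compound 2 and compound 3 shows that the identity of that ring can shift the number by a large amount in either direction. Among the compounds with values here, with no closer precedent, the expectation for compound 4 is a read-out near that of compound 3, with the step of a number 4 percentage points higher from compound 3 to compound 4 (within the scatter) expected to stay within the scatter. Compound 4 is estimated at 35%, within 15% to 55%.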

Compound 4, a percentage reported as inhibition, at one concentration (the size of the read-out at that concentration, not a potency): 24.8%
The estimate for compound 4 lay 10.2 percentage points above the measured number; the range from low to high includes it.
By their numbers in this assay, from the lowest: compounds 1, 4 and 3 (each within the scatter of the next, the first and the last beyond it); then compound 2.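

In this assay, thiophen-2-yl and 4-fluorophenyl on this aromatic carbon of the shared core cannot be told apart, with a number 6.2 percentage points lower from compound 3 to compound 4 (within the scatter). Thiophen-2-yl also cannot be told apart from bromo, with a number 5 percentage points higher from compound 1 to compound 4 (within the scatter), so an aromatic ring at this position does not by itself guarantee a rise beyond the scatter, and compound 4 goes against the pattern suggested by the two earlier aryl-for-bromo steps. The 4-methoxyphenyl group now stands apart from all three other groups shown, with a number 40.4 percentage points lower from compound 2 to compound 4 (beyond the scatter), but no available evidence bears on the reason for this difference.

The compounds shown leave open whether the higher number of compound 2 depends on the methoxy group itself or would also appear with another substituent on the phenyl ring, such as an amine, a hydroxyl group or a longer alkoxy chain. They also leave open how these single-concentration readings relate to potency, and whether a five-membered ring carrying a substituent would behave differently from the unsubstituted thiophen-2-yl.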